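From phenethyl to 4-methylphenyl on the carbonyl carbon

A few compounds are considered here, and "the series" means these few. Any claim that something is new, unique, unknown or untested is made for them only; others in the source may bear on it.

In a functional assay on MGC-803 cells (Homo sapiens) for cytotoxicity, read by MTT assay, with a stated time of 48 h (a lower number here means a stronger inhibitor, a higher number a weaker inhibitor), compound 3 `CC1=NN(C(=O)CCc2ccccc2)C(c2cc(Br)cc(Br)c2O)C1` stands at 17100 nM and compound 1 `CC1=NN(C(=O)c2ccc(C)cc2)C(c2cc(Br)ccc2O)C1` at 21000 nM with the two values within the scatter of each other. Among the compounds with values here, compound 2 `CCC(=O)N1N=C(C)CC1c1cc(Br)cc(Br)c1O` gives 38600 nM and stands apart: a 2.3-fold lower number from compound 2 to compound 3 (0.35 log units; beyond the scatter) is the one measured step, modest in size, with phenyl in place of hydrogen on a saturated chain carbon.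

Compound 4 `CC1=NN(C(=O)c2ccc(C)cc2)C(c2cc(Br)cc(Br)c2O)C1` follows from compound 3 through 4-methylphenyl in place of phenethyl on a carbonyl carbon and so puts 4-methylphenyl in place of phenethyl on a carbonyl carbon. Within the data shown here, no measured step makes this exact change. Both groups hold one six-membered aromatic ring of carbon only, so the modest step offers no ground for a large shift. Compound 1 carries the same 4-methylphenyl on a carbonyl carbon, though on a different core, and gives 21000 nM in the same region as compound 3.

No step beyond the scatter is therefore expected (estimated step: a 1.0-fold lower number from compound 3 to compound 4 (0.00 log units; within the scatter)). The estimate for compound 4 is 17000 nM within an expected range (8000 nM to 35000 nM).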

Compound 4, half-maximal inhibitory concentration: 56500 nM
Compound 4: middle estimate off by 3.3-fold (0.52 log units), on the low side, outside the stated range (above it).
By their numbers in this assay, from the lowest: compounds 3, 1, 2 and 4 (each within the scatter of the next, the first and the last beyond it).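

In this assay, the exchange of phenethyl for 4-methylphenyl on the carbonyl carbon gives a 3.3-fold higher number from compound 3 to compound 4 (0.52 log units; beyond the scatter), so at this position two groups that each hold one six-membered aromatic ring of carbon only are not interchangeable. Against ethyl at the same carbon, 4-methylphenyl gives a 1.5-fold higher number from compound 2 to compound 4 (0.17 log units; within the scatter), within the scatter, which leaves phenethyl as the only one of the three groups on this core that stands apart. Within the data shown here, the one-place bromo exchange, not visible in the earlier steps, gives a 2.7-fold higher number from compound 1 to compound 4 (0.43 log units; beyond the scatter), so the value obtained with 4-methylphenyl on the core of compound 1 does not carry over to this core.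

No measurement at hand accounts for these steps. Still open, going by these compounds, is whether the lower number follows the chain itself, which benzyl or a longer chain ending in phenyl on the carbonyl carbon would test.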